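Changing the Chain End of a Weak Inhibitor

This account rests on a few compounds, and the source may have more. Where it says the series, first, only, none or still open, it means among the compounds named here.

Of the compounds shown here, three have been measured so far in a functional assay on BCG823 cells (Homo sapiens) for antiproliferative activity, read by MTT assay, with a stated time of 48 h; a lower number here means a stronger inhibitor, a higher number a weaker inhibitor. Compound 2 `COc1cc2oc(-c3ccccc3)cc(=O)c2c(O)c1OCCCCN1CCN(C)CC1` gives 53500 nM and compound 3 `CN1CCN(CCCCOc2c(O)cc3oc(-c4ccccc4)cc(=O)c3c2O)CC1` gives 82900 nM, which places this pair together at the high, weak end of the set. Compound 1 `O=c1cc(-c2ccccc2)oc2cc(OCc3ccccc3)c(OCCCN3CCCCC3)c(O)c12` gives 4600 nM, well below both.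

Compound 4 `COc1cc2oc(-c3ccccc3)cc(=O)c2c(O)c1OCCCN1CCCC1` keeps the core of compound 2 but changes the group on its saturated chain: pyrrolidin-1-yl in place of (4-methylpiperazin-1-yl)methyl on a saturated chain carbon, three bonds along the chain from an oxygen on an aromatic ring. Going by the values given here, no measured step touches that place. Among the compounds with values here, the only step available, a 1.5-fold higher number from compound 2 to compound 3 (0.19 log units; within the scatter), concerns a hydrogen in place of methyl on an oxygen on an aromatic ring, so it offers little guidance here beyond showing a change that stays within the scatter. Compound 1 gives a loose hint: it also lacks the 4-methylpiperazin-1-yl group and gives 4600 nM. However, it differs from compound 2 in more than one place, so its lower number cannot be assigned to that group alone.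

A modest move towards a lower number, meaning a stronger inhibitor, is therefore expected in this assay, an estimated 2.7-fold lower number from compound 2 to compound 4 (0.43 log units; beyond the scatter). The estimate for compound 4 is 20000 nM, with an expected range of 6000 nM to 60000 nM.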

Compound 4, half-maximal inhibitory concentration: 6500 nM
Estimate against measurement, compound 4: 3.1-fold (0.49 log units) above; the measured number falls inside the stated range.
By their numbers in this assay, from the lowest: compounds 1 and 4 (each within the scatter of the next); then compounds 2 and 3 (each within the scatter of the next).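

In this assay, putting pyrrolidin-1-yl in place of (4-methylpiperazin-1-yl)methyl gives an 8.2-fold lower number from compound 2 to compound 4 (0.92 log units; beyond the scatter), so the end of the saturated chain is a place where this number can move by more than the scatter. Going by these compounds alone, the only earlier step, a 1.5-fold higher number from compound 2 to compound 3 (0.19 log units; within the scatter), concerned an oxygen on an aromatic ring and stayed within the scatter, so it gave no such sign. Nothing available here explains why this change lowers the number.

Cut one bond further out, the same change reads 3-(4-methylpiperazin-1-yl)propyl to 2-(pyrrolidin-1-yl)ethyl, so the ring and the length of the chain change together, and the compounds shown cannot say which of the two accounts for the step. A 3-(pyrrolidin-1-yl)propyl group at the same place would keep the longer chain of compound 2 with the new ring and so pull the two changes apart, while a morpholine ring at the chain end would test a further ring there.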